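This account rests on a few compounds, and the source may have more. Where it says the series, first, only, none or still open, it means among the compounds named here.

Compound 1 `CC(O)(CSc1ccc(S(F)(F)(F)(F)F)cc1)C(=O)Nc1ccc(S(F)(F)(F)(F)F)cc1` gives 28000 nM in a functional assay on VCaP cells (Homo sapiens) for antiproliferative activity, read by propidium iodide staining, with a stated time of 96 h; on this read-out lower numbers stand for stronger inhibition and higher numbers for weaker inhibition. Compound 2 `CC(O)(CSc1ccc(C(F)(F)F)cc1)C(=O)Nc1ccc(S(F)(F)(F)(F)F)cc1` gives 24800 nM in this assay. The change between them is a group of 4 heavy atoms (1 carbon, 3 fluorine; no ring) in place of a group of 6 heavy atoms (5 fluorine, 1 sulfur; no ring), on an aromatic carbon, and it made a step of a 1.1-fold lower number from compound 1 to compound 2 (0.05 log units; within the scatter). Compound 3 `CC(O)(COc1cccc(S(F)(F)(F)(F)F)c1)C(=O)Nc1ccc(S(F)(F)(F)(F)F)cc1` gives 11400 nM in this assay, the lowest number among the three measured compounds; the difference between the core of compound 3 and the core of compound 1 is not broken down here. Compound 4 `CC(O)(COc1cccc(C(F)(F)F)c1)C(=O)Nc1ccc(S(F)(F)(F)(F)F)cc1` has not yet been measured. It differs from compound 3 by a group of 4 heavy atoms (1 carbon, 3 fluorine; no ring) in place of a group of 6 heavy atoms (5 fluorine, 1 sulfur; no ring), on an aromatic carbon, which is the same kind of change as that from compound 1 to compound 2, though there the group sat para to a large group and here it sits meta to a large group. Because the earlier step was a 1.1-fold lower number from compound 1 to compound 2 (0.05 log units; within the scatter), the step from compound 3 to compound 4 is expected to be a 1.0-fold lower number from compound 3 to compound 4 (0.02 log units; within the scatter). Compound 4 is therefore estimated at 11000 nM, within 5000 nM to 25000 nM.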

Compound 4, half-maximal inhibitory concentration: 24700 nM
Estimate against measurement, compound 4: 2.2-fold (0.35 log units) below, within the range that was stated.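

In this assay, replacing the group of 5 fluorine and 1 sulfur atoms with trifluoromethyl gave a 2.2-fold higher number from compound 3 to compound 4 (0.34 log units; beyond the scatter), a modest step. Set beside the same change on the other core, this step does not differ from the earlier one by more than repeated measurements could explain: the same change on two cores in this assay, a 1.1-fold lower number (0.05 log units; within the scatter) from compound 1 to compound 2 and a 2.2-fold higher number (0.34 log units; beyond the scatter) from compound 3 to compound 4, 2.4-fold (0.39 log units) apart, within the scatter of two such steps. This gives no sign that the core alters the effect of the change, but two pairs cannot prove that the effect carries over unchanged, and they do not explain the step.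

As far as these compounds go, the two cores differ in more than one place, so what each difference contributes remains open. Also open, from the compounds shown here alone, is how a smaller group, such as a chlorine atom or a nitrile, would behave in the same place.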